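This account rests on a few compounds, and the source may have more. Where it says the series, first, only, none or still open, it means among the compounds named here.

In a functional assay on ileum (Cavia porcellus) for antagonist activity, with a stated time of 30 s (a higher number here means a weaker inhibitor, a lower number a stronger inhibitor), compound 1 (`O=C(O)c1cc(=O)c2ccc(OCCCCCOc3cccc(O)c3)cc2o1`) gives 1.5 ug/mL, and compound 2 (`O=C(O)c1cc(=O)c2ccc(OCCCCCOc3cccc(OCc4ccccc4)c3)cc2o1`) gives 1 ug/mL. These two values lie within the scatter of each other, so compound 1 has no meaningful rank on these numbers. Among the compounds with values here, the only measured step is a 1.5-fold lower number from compound 1 to compound 2 (0.18 log units; within the scatter), with benzyl in place of hydrogen on an oxygen on an aromatic ring. Compound 3 (`CC(=O)c1ccc(OCCCCCOc2ccc3c(=O)cc(C(=O)O)oc3c2)cc1O`) differs from compound 1 by acetyl in place of hydrogen on an aromatic carbon. This acetyl sits on an aromatic carbon, ortho to a hydroxy group and para to a large group, turning 3-hydroxyphenyl into 4-acetyl-3-hydroxyphenyl. The measured step involves a different change, so it bears only loosely on this one, and no acetyl change has been measured. No shift beyond the scatter is therefore expected in this assay, and the estimated step is a 1.9-fold lower number from compound 1 to compound 3 (0.27 log units; within the scatter). For compound 3, the expected value is 0.8 ug/mL, with an estimated range of 0.2 ug/mL to 3 ug/mL.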

Compound 3, half-maximal inhibitory concentration: 6.8 ug/mL
The estimate for compound 3 lay 8.5-fold (0.93 log units) below the measured number; measured number outside the range, above it.
By their numbers in this assay, from the lowest: compounds 2 and 1 (each within the scatter of the next); then compound 3.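

In this assay, within the data shown here, acetyl in place of hydrogen on an aromatic carbon, ortho to a hydroxy group and para to a large group, gives a 4.5-fold higher number from compound 1 to compound 3 (0.66 log units; beyond the scatter), the only step here that lies beyond the scatter. Among these compounds, the earlier step, a 1.5-fold lower number from compound 1 to compound 2 (0.18 log units; within the scatter), changed only what sits on the oxygen, so this is the first sign that a change on the aromatic carbon itself can move the number, and it moves towards weaker inhibition. No measurement at hand accounts for this shift.

The compounds shown leave open whether the shift belongs to acetyl itself or would follow any group on this carbon. Going by these compounds, a methyl, a chlorine or an amine there would separate those readings, and the effect of acetyl alongside the benzyl group of compound 2 also remains open.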